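A few compounds are considered here, and "the series" means these few. Any claim that something is new, unique, unknown or untested is made for them only; others in the source may bear on it.

In a functional assay on CCRF-CEM cells (Homo sapiens) for antiproliferative activity, read by trypan blue exclusion, with a stated time of 72 h (a higher number here means a weaker inhibitor, a lower number a stronger inhibitor), compound 3 (`NC(=O)NC(=O)c1cc(NC(=O)CBr)ccc1F`) gives < 10 nM, a limit of the assay. Compound 1 (`CC(Br)C(=O)Nc1ccc(F)c(C(=O)NC(N)=O)c1`) gives 520 nM. For the measured compounds named here, the only measured step, an at least 52-fold lower number from compound 1 to compound 3 (1.71 log units; beyond the scatter), is large but lies on the bromine-bearing chain, so it does not cover the change now in question. Compound 4 (`COc1ccc(NC(=O)CBr)cc1C(=O)NC(N)=O`) carries methoxy in place of fluoro on an aromatic carbon. Differing from compound 1 in more than one place and carrying methoxy, compound 2 (`COc1ccc(C(=O)NC(N)=O)cc1NC(=O)C(C)Br`) gives > 20000 nM, a limit, and this is the only methoxy evidence, so a weaker result is expected in this assay. The estimated change, beyond the scatter, is an at least 15-fold higher number from compound 3 to compound 4 (1.17 log units; beyond the scatter). For compound 4 the estimate is 150 nM, with an expected range of 15 nM to 1500 nM.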

Compound 4, half-maximal inhibitory concentration: 1570 nM
Compound 4: the middle estimate sits 10-fold (1.02 log units) below what was measured; the measured number lies above the stated range.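

In this assay, for the compounds shown here, this is the first single-place change read on the aromatic carbon ortho to the carbamoylcarbamoyl group, and with the ((bromomethyl)carbonyl)amino group held constant, the position proves far from indifferent: an at least 150-fold higher number from compound 3 to compound 4 (2.19 log units; beyond the scatter). Compound 3 gives < 10 nM, a limit of the assay. The step therefore sets only a floor on the size of the change, since one end of it rests on that limit: the limit of < 10 nM in this assay, at which 1 of the 4 values shown sits.

As far as these compounds go, whether the weaker result follows from gaining methoxy or losing fluoro stays open. Hydrogen, chloro or ethoxy on this carbon would separate the two readings.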